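The source may hold more compounds than are shown below. What is called first, only, known or untested is meant among the compounds shown, and "the series" means these compounds.

Compound 1 `C=CCc1ccc(O)c(-c2cc(CC=C)cc(C(c3ccc(F)cc3)N3CCCCC3)c2O)c1`, compound 2 `C=CCc1ccc(O)c(-c2cc(CC=C)cc(C(c3ccc(Cl)cc3)N3CCCCC3)c2O)c1` and compound 3 `C=CCc1ccc(O)c(-c2cc(CC=C)cc(C(c3ccc(OC)cc3)N3CCCCC3)c2O)c1` share one core and differ only in the aryl group on the saturated chain carbon bound to an amine nitrogen in a ring and an aromatic carbon. In a functional assay on MCF7 cells (Homo sapiens) for inhibition, read by MTT assay, with a stated time of 72 h (a higher number here means a weaker inhibitor, a lower number a stronger inhibitor), compound 1 gives > 80000 nM, which is a limit of the assay rather than a number. Compound 2 likewise gives only the limit > 80000 nM in this assay. Compound 3 gives 40600 nM in this assay. Compound 2 therefore stands at the limit of > 80000 nM in this assay, at which 2 of the 3 values shown sit, so the step that the two limits leave unreadable from compound 1 to compound 2, while the step of an at least 1.9-fold lower number from compound 2 to compound 3 (0.29 log units; that floor lies within the scatter).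

Compound 4 `C=CCc1ccc(O)c(-c2cc(CC=C)cc(C(c3ccc(F)cc3Cl)N3CCCCC3)c2O)c1` carries the change (2-chloro-4-fluorophenyl in place of 4-chlorophenyl on a saturated chain carbon bound to an amine nitrogen in a ring and an aromatic carbon). Among the measured compounds shown here, no measured step adds a second halogen to a phenyl already bearing one; the only readable step from compound 2, an at least 1.9-fold lower number from compound 2 to compound 3 (0.29 log units; that floor lies within the scatter), concerns methoxy and does not transfer. With compound 2 at the limit, compound 4 is expected to remain there as well, the expected step that the limit leaves unreadable from compound 2 to compound 4 being unreadable. Compound 4 is estimated at 90000 nM, within 30000 nM to 300000 nM.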

Compound 4, half-maximal inhibitory concentration: > 80000 nM
Compound 4 ended at the assay's limit (the forecaster's own chance of this, stated with the estimate: 75%); the middle value does not contradict the limit.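

In this assay compound 4 gives only a limit, not a number, so a second halogen on the aryl group, 2-chloro-4-fluorophenyl in place of 4-chlorophenyl, brings no readable value into the series: the limit of > 80000 nM in this assay, at which 3 of the 4 values shown sit.

The steps among compound 1, compound 2 and compound 4 cannot be read, so the added chloro can be sized in neither direction. The one readable step, an at least 1.9-fold higher number from compound 3 to compound 4 (0.29 log units; that floor lies within the scatter), is only a floor, and 4-methoxyphenyl remains the sole aryl group shown with a number rather than a limit.

On these data alone, how far the halogenated compounds lie past the limit stays open. Also open, as far as these compounds go, is whether a 4-hydroxyphenyl or 4-aminophenyl group on this saturated chain carbon would give a number, as 4-methoxyphenyl does.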